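Amino on the Core: Expectation for Compound 4

A few compounds are considered here, and "the series" means these few. Any claim that something is new, unique, unknown or untested is made for them only; others in the source may bear on it.

Measured so far:
- compound 1 `Cn1c(-c2ccc(Cl)c(Cl)c2)cc2ccccc21` gives 20% in an assay on isolated protein for inhibition of Aromatase (Homo sapiens), read by fluorescence, using NADPH, with a stated time of 30 min, tested at 50 uM; on this read-out higher numbers stand for more inhibition at the one concentration tested (going by the name of the read-out) and lower numbers for less inhibition
- compound 2 `CO/N=C/c1c(-c2ccccc2)[nH]c2ccccc12` gives 24.7%
- compound 3 `COc1ccc2ccc(-c3cc4ccccc4[nH]3)cc2c1` gives 0.07%

Compound 1 stands second highest of the three numbers. Its nearest neighbour is compound 2, which lies within the usual scatter, so no order between the two can be stated. The furthest is compound 3, whose number is lower by an amount beyond the scatter.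

Compound 4 `Cn1c(-c2ccc(Cl)c(Cl)c2)cc2cc(N)ccc21` is not yet measured. It differs from compound 1 in one place: amino in place of hydrogen on an aromatic carbon. The dichlorophenyl and the methyl on the core are kept; only the amino enters on the six-membered aromatic ring of the fused system.

Among the measured compounds shown here, no step between measured compounds touches this change, so nothing tells how such an addition moves the read-out. The expectation is therefore for no shift beyond the scatter, with a number 5 percentage points higher from compound 1 to compound 4 (within the scatter) as the estimated step. For compound 4 the estimate is 25%, with a range from 8% to 45%.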

Compound 4, a percentage reported as inhibition, at one concentration (the size of the read-out at that concentration, not a potency): 42%
Compound 4: middle estimate off by 17 percentage points, on the low side; the range from low to high includes it.
By their numbers in this assay, from the lowest: compound 3; then compounds 1 and 2 (each within the scatter of the next); then compound 4.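

In this assay, amino in place of hydrogen gives a number 22 percentage points higher from compound 1 to compound 4 (beyond the scatter), the first sign in the series that this carbon of the six-membered aromatic ring, part of the fused system, can move the read-out. Among the compounds shown here, the dichlorophenyl and the methyl on the core are kept, so this step belongs to the single change of hydrogen to amino and shows that the position accepts a group carrying nitrogen without loss of inhibition. Nothing measured here bears on what lies behind the step.

From the compounds shown here alone, it remains open whether a hydroxyl, a methoxy or an acetamide on the same carbon would give a similar step, or whether the step depends on amino itself. Also open, going by these compounds, is whether amino on another carbon of this ring, or on the core of compound 2, would move the read-out in the same direction.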